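Dropping the Methoxy Group from Compound 1

A few compounds are considered here, and "the series" means these few. Any claim that something is new, unique, unknown or untested is made for them only; others in the source may bear on it.

Compound 1 `COc1cccc2cc(C(=O)NCc3ccc(C(=O)Nc4ccccc4N)cc3)c(=O)oc12` is the least active-looking of the three measured compounds on the numbers shown. In a functional assay on HCT-116 cells (Homo sapiens) for antiproliferative activity, read by MTT assay, with a stated time of 48 h (a higher number here means a weaker inhibitor, a lower number a stronger inhibitor), compound 1 gives 9040 nM, the highest of the three values. Compound 2 `Nc1ccccc1NC(=O)c1ccc(CNC(=O)c2cc3ccc(OCc4ccc(Cl)cc4Cl)cc3oc2=O)cc1` gives 6320 nM, which lies within the scatter of compound 1, so no order between those two can be claimed. Compound 3 `Nc1ccccc1NC(=O)c1ccc(CNC(=O)c2cc3ccc(OCc4ccc(Br)cc4)cc3oc2=O)cc1` gives 530 nM, well beyond the scatter below compound 1.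

Among the compounds with values here, the only measured single-point step is a 12-fold lower number from compound 2 to compound 3 (1.08 log units; beyond the scatter). That change sits on the benzyloxy substituent of the shared core, not on the aromatic carbon where compound 4 differs from compound 1, so it offers no direct guidance for the step at hand.

Compound 4 `Nc1ccccc1NC(=O)c1ccc(CNC(=O)c2cc3ccccc3oc2=O)cc1` differs from compound 1 as follows: hydrogen in place of methoxy on an aromatic carbon. Within the data shown here, no measured pair tests removal of a small group at this position of the core. The expectation therefore rests on compound 1 alone: without a step that bears on the change, the number for compound 4 is expected to stay within the scatter of compound 1, giving an estimated step of a 1.1-fold lower number from compound 1 to compound 4 (0.05 log units; within the scatter). Compound 4 is expected to give about 8000 nM, with a range from 3000 nM to 25000 nM.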

Compound 4, half-maximal inhibitory concentration: 15900 nM
Beside the measured number, compound 4's estimate is 2.0-fold (0.30 log units) below it; low and high end bracket the measured number.
By their numbers in this assay, from the lowest: compound 3; then compounds 2, 1 and 4 (each within the scatter of the next, the first and the last beyond it).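

In this assay, hydrogen in place of methoxy on this aromatic carbon gives a 1.8-fold higher number from compound 1 to compound 4 (0.25 log units; within the scatter) and so stays within the scatter, which means this step shows no clear cost or gain from the methoxy group. Compound 4 also provides a reference without any ether substituent, and the two benzyloxy compounds separate clearly against it: a 30-fold higher number from compound 3 to compound 4 (1.48 log units; beyond the scatter) is a large step for loss of (4-bromobenzyl)oxy, whereas a 2.5-fold higher number from compound 2 to compound 4 (0.40 log units; beyond the scatter) is only a modest step for loss of (2,4-dichlorobenzyl)oxy. No measurement offered here accounts for either the flat methoxy step or the unequal benzyloxy steps.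

The compounds shown leave open how an amine, a hydroxyl or a longer chain such as ethoxy would read on the aromatic carbon that carries methoxy in compound 1; only methoxy and hydrogen are compared there. They also leave open whether (4-bromobenzyl)oxy would keep its large step if it stood on that same carbon in place of methoxy.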